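From Acetoxy to Acetamido on a Double-Bonded Nitrogen

The source may report more compounds than this note shows. Statements on the series, on what has been measured and on what is new or still open speak of the compounds shown alone.

Of the compounds shown here, two of this set have been tested in a functional assay on HeLa cells (Homo sapiens) for cytotoxicity, read by XTT assay, with a stated time of 72 h; on this read-out higher numbers stand for weaker inhibition and lower numbers for stronger inhibition. Compound 1 `CCn1ccc2cc(C(O)c3ccc(OC)c(OC)c3OC)ccc21` is recorded only as a limit of the assay: in this assay compound 1 gives < 1000 nM. Going by the values given here, compound 2 `COc1ccc(/C(=N\OC(C)=O)c2ccc3c(ccn3C)c2)c(OC)c1OC` gives 1000 nM in this assay, and this is the only numerical value shown for the set. The remaining entry, that of compound 1, is a limit of the assay, namely (the limit of < 1000 nM in this assay, at which 1 of the 2 values shown sits). Among the compounds with values here, no two measured compounds differ in a single place, so no measured step can be read from these data. Compound 3 `COc1ccc(/C(=N\NC(C)=O)c2ccc3c(ccn3C)c2)c(OC)c1OC` has not yet been measured. It differs from compound 2 by acetamido in place of acetoxy on a double-bonded nitrogen, in words acetamido in place of acetoxy on a double-bonded nitrogen. Within the data shown here, with no measured step to lean on, the change is expected to move the number only modestly, and the step from compound 2 to compound 3 is estimated as a 1.2-fold higher number from compound 2 to compound 3 (0.08 log units; within the scatter), of a size that lies within the usual scatter. Compound 3 is therefore expected to give about 1200 nM in this assay, within a range from 400 nM to 4000 nM.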

Compound 3, half-maximal inhibitory concentration: 1000 nM
Compound 3: the middle estimate sits 1.2-fold (0.08 log units) above what was measured; the range from low to high includes it.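

In this assay, going by these compounds alone, the exchange of acetoxy for acetamido on a double-bonded nitrogen gives the first step that can be read in this set, with no change at the digits printed from compound 2 to compound 3 (within the scatter) as its result. The acetamido group brings a hydrogen-bond donor that acetoxy does not have, and at this place that difference in the group comes with no readable difference in the read-out, which compound 1 and compound 2 alone could not show. Nothing measured here accounts for this outcome.

Within the data shown here, compound 1 is recorded only as a limit of the assay, < 1000 nM, and no step to it can be read. On these data alone, it remains open whether a longer chain, an amine or a carboxylic acid in place of acetamido on the double-bonded nitrogen would leave the number as flat as this exchange did, and whether the same exchange would read the same way on a different core.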